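One group exchanged: from compound 2 to compound 4

A few compounds are considered here, and "the series" means these few. Any claim that something is new, unique, unknown or untested is made for them only; others in the source may bear on it.

In a functional assay on PC-3 cells (Homo sapiens) for cytotoxicity, read by MTT assay, with a stated time of 72 h (a higher number here means a weaker inhibitor, a lower number a stronger inhibitor), compound 2 (`COc1ccc(OC)c(/C=C/C(=O)Nc2cc3c(Nc4ccc(F)c(Cl)c4)ncnc3cc2OC)c1`) gives 28600 nM. That lies within the scatter of compound 1 (`COc1cc2ncnc(Nc3ccc(F)c(Cl)c3)c2cc1NC(=O)/C=C/c1ccc(F)cc1Cl`) at 32700 nM and of compound 3 (`O=C(/C=C/c1cccc(Cl)c1Cl)Nc1cc2c(Nc3ccc(F)c(Cl)c3)ncnc2cc1O[C@H]1CCOC1`) at 27500 nM, so the three values cannot be ranked. Compound 4 (`COc1ccc(/C=C/C(=O)Nc2cc3c(Nc4ccc(F)c(Cl)c4)ncnc3cc2OC)cc1`) carries 4-methoxyphenyl in place of 2,5-dimethoxyphenyl on a double-bonded chain carbon bound to a double-bonded chain carbon. Going by the values given here, one measured step bears on this position, a 1.1-fold lower number from compound 1 to compound 2 (0.06 log units; within the scatter), an exchange of the group at the same place that stayed within the scatter. On that single step, the expected change is a 1.1-fold lower number from compound 2 to compound 4 (0.03 log units; within the scatter), with no shift beyond the scatter anticipated in either direction. For compound 4 the estimated value is 27000 nM, with an expected range from 12000 nM to 55000 nM.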

Compound 4, half-maximal inhibitory concentration: "not active" (no number reported)
Nothing numeric was reported for compound 4; the estimate stays without a comparison.
By their numbers in this assay, from the lowest: compounds 3, 2 and 1 (each within the scatter of the next).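

Compound 4 was reported as "not active" in this assay with no number, so no step can be read from compound 2, at 28600 nM, to compound 4. No evidence bears on this result. The compounds shown leave open whether 4-methoxyphenyl in place of 2,5-dimethoxyphenyl shifts the number at all.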